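Ester for Amide: Expecting a Loss in Stability

A few compounds are considered here, and "the series" means these few. Any claim that something is new, unique, unknown or untested is made for them only; others in the source may bear on it.

Three measured compounds share one core. In an ADME assay on cells (Hepatocyte, Mus musculus) for metabolic stability, with a stated time of 30 min (on this read-out lower numbers stand for a less stable compound and higher numbers for a more stable compound), compound 1 `O=C(NC1CCC(CN2CCN(c3cc(=O)c4cc(C(F)(F)F)cc([N+](=O)[O-])c4s3)CC2)CC1)c1ccccc1` gives 90.6% and stands highest of the three numbers. Compound 2 `Cc1ccc(C(=O)OC2CCC(CN3CCN(c4cc(=O)c5cc(C(F)(F)F)cc([N+](=O)[O-])c5s4)CC3)CC2)cc1` gives 18%, and compound 3 `CC(=O)OC1CCC(CN2CCN(c3cc(=O)c4cc(C(F)(F)F)cc([N+](=O)[O-])c4s3)CC2)CC1` gives 0%. The step of a number 72.6 percentage points lower from compound 1 to compound 2 (beyond the scatter) is large, and the step of a number 90.6 percentage points lower from compound 1 to compound 3 (beyond the scatter) is larger still; the step of a number 18 percentage points lower from compound 2 to compound 3 (beyond the scatter) is modest. Compound 4 `COc1ccc(C(=O)OC2CCC(CN3CCN(c4cc(=O)c5cc(C(F)(F)F)cc([N+](=O)[O-])c5s4)CC3)CC2)cc1` differs from compound 1 in one place: ((4-methoxyphenyl)carbonyl)oxy in place of benzamido on a saturated ring carbon. Because the swap of benzamido for an ester in a number 72.6 percentage points lower from compound 1 to compound 2 (beyond the scatter) brought a large fall, a fall of similar size is expected here, with the step of a number 75.6 percentage points lower from compound 1 to compound 4 (beyond the scatter). Compound 4 is therefore estimated to give 15%, expected to lie between 0% and 45%.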

Compound 4, percent of the compound remaining: 31%
Compound 4: middle estimate off by 16 percentage points, on the low side; the range from low to high includes it.
By their numbers in this assay, from the lowest: compound 3; then compound 2; then compound 4; then compound 1.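

In this assay, a third ester also sits well below the amide, with a number 59.6 percentage points lower from compound 1 to compound 4 (beyond the scatter). The group on the ester carbonyl carbon also changes the number: 4-methoxyphenyl in place of methyl gives a number 31 percentage points higher from compound 3 to compound 4 (beyond the scatter), and methoxy in place of methyl on the aromatic carbon gives the smaller a number 13 percentage points higher from compound 2 to compound 4 (beyond the scatter). Nothing measured here explains these steps. Still open, as far as these compounds go, is whether a 4-methoxybenzamido group would keep the number of compound 1, and how a carbamate or an ether at this ring carbon would compare.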